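The compounds below may be only part of what the source reports. "The series", "measured", "known", "first", "only" and "open" are said of these compounds alone.

Measured compounds in an ADME assay on S9 fraction from liver (Rattus norvegicus), read by LC-MS, with a stated time of 60 min, at 37 degrees C; a higher number here means that more of the compound is left, a lower number that less of the compound is left:
- compound 1, `CCOC(=O)N1CCN(C(=O)c2nc(Nc3cc(C4CC4)[nH]n3)c3cc(Cl)ccc3n2)C[C@H]1C`, gives 48.5%
- compound 2, `C[C@@H]1CN(C(=O)c2nc(Nc3cc(C4CC4)[nH]n3)c3cc(Cl)ccc3n2)CCN1C(=O)OC(C)(C)C`, gives 71.3%
- compound 3, `CCCCCOC(=O)N1CCN(C(=O)c2nc(Nc3cc(C4CC4)[nH]n3)c3cc(Cl)ccc3n2)C[C@H]1C`, gives 63.9%

Compound 3 stands second highest of the three. Its nearest neighbour is compound 2, with a step of a number 7.4 percentage points lower from compound 2 to compound 3 (within the scatter), and its furthest is compound 1, with a step of a number 15.4 percentage points higher from compound 1 to compound 3 (beyond the scatter). The other measured step, a number 22.8 percentage points higher from compound 1 to compound 2 (beyond the scatter), also changes only the group on the oxygen next to the carbonyl.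

Compound 4, `CC(OC(=O)C(C)C)OC(=O)N1CCN(C(=O)c2nc(Nc3cc(C4CC4)[nH]n3)c3cc(Cl)ccc3n2)C[C@H]1C`, differs from compound 3 as follows: 1-((isopropylcarbonyl)oxy)ethyl in place of pentyl on an oxygen next to a carbonyl group. All three measured steps sit at this same oxygen, but each of them exchanges one plain alkyl group for another, and the three values span a modest range. Going by the values given here, none of them brings in a group with a carbonyl and two oxygens, so no measured step matches this change directly, and the expectation for compound 4 rests on a wide range. The estimate for compound 4 in this assay is a step of a number 23.9 percentage points lower from compound 3 to compound 4 (beyond the scatter), downward, giving an expected 40% within 15% to 65%.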

Compound 4, percent of the compound remaining: 11%
For compound 4 the middle estimate is 29 percentage points above the measured one; measured number below the stated range.
By their numbers in this assay, from the lowest: compound 4; then compound 1; then compounds 3 and 2 (each within the scatter of the next).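

In this assay, going by these compounds alone, 1-((isopropylcarbonyl)oxy)ethyl on this oxygen next to a carbonyl group gives the lowest number so far, with a number 52.9 percentage points lower from compound 3 to compound 4 (beyond the scatter) and a number 60.3 percentage points lower from compound 2 to compound 4 (beyond the scatter) and a number 37.5 percentage points lower from compound 1 to compound 4 (beyond the scatter) as its steps. Ethyl, tert-butyl and pentyl had shown only a modest range at this position, and the entering group now shows that a single change here can produce large steps. Nothing available here accounts for the size of these steps.

The compounds shown leave open whether the isopropylcarbonyl part or the carbon that carries it goes with the low number. A 1-methoxyethyl or an acetoxymethyl group on the same oxygen would separate those two parts.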